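Changing the group on sulfur in compound 4

The compounds below may be only part of what the source reports. "The series", "measured", "known", "first", "only" and "open" are said of these compounds alone.

Within the data shown here, in a functional assay on SW-620 cells (Homo sapiens) for cytotoxicity, read by MTT assay, with stated times of 4 h and 72 h, tested at 2 uM (a higher number here means a weaker inhibitor, a lower number a stronger inhibitor), compound 3 (`Cc1cc(Nc2ccc(C(=O)/C=C/c3ccc4ccccc4c3)cc2)n2nc(SC(=O)c3csc4ccc(Cl)cc34)nc2n1`) gives 35 nM as the lowest number of the three compounds measured so far. Compound 4 (`Cc1cc(Nc2ccc(C(=O)/C=C/c3ccc4ccccc4c3)cc2)n2nc(SCc3nc4ccccc4[nH]3)nc2n1`) has not yet been measured. It carries (1H-benzimidazol-2-yl)methyl in place of (5-chloro-1-benzothiophen-3-yl)carbonyl on a sulfur and otherwise matches compound 3. Compound 1 (`COc1ccc(/C=C/C(=O)c2ccc(Nc3cc(C)nc4nc(SCc5nc6ccccc6[nH]5)nn34)cc2)cc1F`) at 140 nM and compound 2 (`Cc1cc(Nc2ccc(C(=O)/C=C/c3ccc(F)cc3)cc2)n2nc(SCc3nc4ccccc4[nH]3)nc2n1`) at 85 nM already carry the entering group, and both numbers are higher than that of compound 3, but these two compounds also differ from it elsewhere. Among the measured compounds shown here, the only measured step, a 1.6-fold lower number from compound 1 to compound 2 (0.22 log units; within the scatter), swaps 4-fluorophenyl for 3-fluoro-4-methoxyphenyl and lies within the scatter, so no measured step isolates the change on sulfur. Those two values alone suggest a move toward a weaker inhibitor, and the evidence for it is indirect. The expected step in this assay is a 2.3-fold higher number from compound 3 to compound 4 (0.36 log units; beyond the scatter) toward a higher number. Compound 4 is estimated at 80 nM with a range from 30 nM to 200 nM in this expectation.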

Compound 4, half-maximal inhibitory concentration: 5 nM
For compound 4 the middle estimate is 16-fold (1.20 log units) above the measured one; the whole stated range lies above it.
By their numbers in this assay, from the lowest: compound 4; then compound 3; then compounds 2 and 1 (each within the scatter of the next).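

With naphthalen-2-yl held constant, the change on sulfur can now be read on its own in this assay: (1H-benzimidazol-2-yl)methyl in place of (5-chloro-1-benzothiophen-3-yl)carbonyl gives a 7.0-fold lower number from compound 3 to compound 4 (0.85 log units; beyond the scatter). The group on this sulfur therefore matters, and here the entering group gives the stronger inhibitor. With (1H-benzimidazol-2-yl)methyl kept on sulfur, the group on the double-bonded chain carbon matters as well: naphthalen-2-yl gives a 17-fold lower number from compound 2 to compound 4 (1.23 log units; beyond the scatter) in place of 4-fluorophenyl and a 28-fold lower number from compound 1 to compound 4 (1.45 log units; beyond the scatter) in place of 3-fluoro-4-methoxyphenyl.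

No supporting measurement accounts for these steps. Still open, going by these compounds, is how a plain benzyl group or a longer chain ending in 1H-benzimidazol-2-yl would fare on this sulfur, and whether the step on sulfur keeps its size with 4-fluorophenyl in place of naphthalen-2-yl.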